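Isopentyl for isobutylcarbonyl on the aromatic oxygen

A few compounds are considered here, and "the series" means these few. Any claim that something is new, unique, unknown or untested is made for them only; others in the source may bear on it.

Measured so far in a functional assay on A549 cells (Homo sapiens) for cytotoxicity, with a stated time of 48 h (a lower number here means a stronger inhibitor, a higher number a weaker inhibitor), for this series:
- compound 1 `CC(C)CC(=O)Oc1ccc2oc(/C=C/[S+](C)[O-])cc(=O)c2c1` gives 2300 nM
- compound 2 `Cc1cccc2c(=O)cc(/C=C/[S+](C)[O-])oc12` gives 1700 nM
- compound 3 `COc1cccc2oc(/C=C/[S+](C)[O-])cc(=O)c12` gives 3800 nM

Compound 1 lies within the scatter of both compound 2 and compound 3 in this assay and so has no clear rank among the three. Compound 4 `CC(C)CCOc1ccc2oc(/C=C/[S+](C)[O-])cc(=O)c2c1` differs from compound 1 by isopentyl in place of isobutylcarbonyl on an oxygen on an aromatic ring and awaits measurement. Within the data shown here, no measured pair isolates a change at this oxygen, so the expectation is only indirect. With compound 2 at 1700 nM and compound 3 at 3800 nM both within the scatter of compound 1, no step beyond the scatter is expected in this assay for this change. The expected step of a 1.1-fold higher number from compound 1 to compound 4 (0.04 log units; within the scatter) is small, and its direction is uncertain. For compound 4 the estimate is 2500 nM with an expected range from 900 nM to 7000 nM in this assay once tested.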

Compound 4, half-maximal inhibitory concentration: 1000 nM
Compound 4: the middle estimate sits 2.5-fold (0.40 log units) above what was measured; low and high end bracket the measured number.
By their numbers in this assay, from the lowest: compounds 4, 2, 1 and 3 (each within the scatter of the next, the first and the last beyond it).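

Among these compounds, the oxygen on the aromatic ring now gives the first single-place step: in this assay, isopentyl in place of isobutylcarbonyl gives a change beyond the scatter (a 2.3-fold lower number from compound 1 to compound 4 (0.36 log units; beyond the scatter)). At this position the carbonyl is therefore not needed for cytotoxicity in these cells, and its removal goes with a lower number. Nothing at hand accounts for the step.

The compounds shown do not separate loss of the carbonyl from the shape of the chain. Ethyl or a longer chain on this oxygen, or an amine at the chain end, remains open.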